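Pyrazoline paw-edema series: phenyl on ring nitrogen, pyridyl swapped

The source may report more compounds than this note shows. Statements on the series, on what has been measured and on what is new or still open speak of the compounds shown alone.

Measured so far:
compound 1 `CN(C)c1ccc(C2CC(c3ccncc3)=NN2)cc1` — 0%
compound 2 `CN(C)c1ccc(C2CC(c3cccnc3)=NN2c2ccccc2)cc1` — 34%

In a functional assay on the whole organism (strain Charles Foster albino) for inhibition, with Rattus norvegicus as the target, read by paw edema, with stated times of 30 min and 3 h, at a dose of 50 mg/kg by the oral route (a lower number here means less inhibition, a higher number more inhibition at the dose given (going by the name of the read-out)), compound 1 gives 0%, while compound 2 gives 34%, the higher of the two numbers and beyond the scatter of compound 1. Compound 3 `CN(C)c1ccc(C2CC(c3ccncc3)=NN2c2ccccc2)cc1` is not yet measured. It differs from compound 2 by pyridin-4-yl in place of pyridin-3-yl on a carbon with a double bond to nitrogen. Among the compounds with values here, no pair differing in one place has been measured, so the size of this step is unknown; compound 1, which also carries a pyridin-4-yl group, sits at 0%. A moderate fall is expected, giving a number 9 percentage points lower from compound 2 to compound 3 (within the scatter) in this assay. Compound 3 is estimated at 25%, between 5% and 45%.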

Compound 3, a percentage reported as inhibition, in the whole organism at one dose (the size of the read-out at that dose, not a potency): 32%
Compound 3: middle estimate off by 7 percentage points, on the low side; low and high end bracket the measured number.
By their numbers in this assay, from the lowest: compound 1; then compounds 3 and 2 (each within the scatter of the next).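

In this assay, pyridin-4-yl in place of pyridin-3-yl on the carbon with a double bond to nitrogen gives a number 2 percentage points lower from compound 2 to compound 3 (within the scatter), so the two pyridyl groups cannot be told apart here when the ring nitrogen carries phenyl. The large change lies at that ring nitrogen instead: phenyl in place of hydrogen gives a number 32 percentage points higher from compound 1 to compound 3 (beyond the scatter). Nothing measured here explains either step.

As far as these compounds go, it remains open whether a pyridin-2-yl or a plain phenyl group on that carbon would score similarly. From the compounds shown here alone, it is also open whether a smaller methyl or acetyl group on the ring nitrogen would keep the gain.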